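The compounds below may be only part of what the source reports. "The series", "measured", "known", "first", "only" and "open" are said of these compounds alone.

Three compounds have values so far in a physicochemical assay for solubility, in phosphate buffer, at pH 7.4; on this read-out lower numbers stand for lower solubility and higher numbers for higher solubility

Compound 1 (`O=C(Nc1ccc(C(F)(F)F)cc1)NC1CCN(C(=O)C2CC2)CC1`) gives 19.7 ug/mL
Compound 2 (`CCC(C)C(=O)N1CCC(NC(=O)Nc2ccc(C(F)(C(F)(F)F)C(F)(F)F)cc2)CC1`) gives 0.17 ug/mL
Compound 3 (`CCC(C)C(=O)N1CCC(NC(=O)NC2CCCCC2)CC1`) gives 923 ug/mL

Compound 3 stands highest of the three on this assay and lies beyond the scatter from both others, with compound 1 nearest to it and compound 2 furthest away. Compound 4 (`CCC(C)C(=O)N1CCC(NC(=O)NC2CCCCCC2)CC1`) carries cycloheptyl in place of cyclohexyl on an amide-type nitrogen and is otherwise identical to compound 3. It has not yet been measured. Among the compounds with values here, no two measured compounds differ in one place only, so the data offer no direct guide to a step of this kind. The measured values span a wide range, with compound 2 at 0.17 ug/mL and compound 3 at 923 ug/mL but those compounds differ by far more than this single exchange. A modest fall is expected, and the estimated 2.1-fold lower number from compound 3 to compound 4 (0.31 log units; beyond the scatter) lies near the edge of the usual scatter. For compound 4 the estimate is 450 ug/mL with an expected range from 180 ug/mL to 1000 ug/mL as the likely span.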

Compound 4, solubility: 278 ug/mL
Compound 4: the middle estimate sits 1.6-fold (0.21 log units) above what was measured; low and high end bracket the measured number.
By their numbers in this assay, from the lowest: compound 2; then compound 1; then compound 4; then compound 3.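

In this assay, within the data shown here, the exchange of cyclohexyl for cycloheptyl on an amide-type nitrogen gives a 3.3-fold lower number from compound 3 to compound 4 (0.52 log units; beyond the scatter), the first step in this set that can be read at a single place. The earlier compounds shown here differ from one another in more than one place, so their wide spread could not be tied to any one part of the structure. This pair shows that, with the rest of the molecule held fixed, going from a six-membered to a seven-membered non-aromatic ring of carbon at this position is enough to carry the number beyond the scatter, though the step remains modest, and nothing measured here bears on the reason for it.

The compounds shown leave open whether the trend extends in the other direction to a cyclopentyl ring, or whether an open chain such as n-hexyl, or a ring carrying a hydroxyl group or an amine, would follow it. They also leave open whether the same ring exchange gives a step of similar size when the acyl group on the shared core is a different one, such as cyclopropanecarbonyl.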